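Three Limits and One Unmeasured Compound

The source may hold more compounds than are shown below. What is called first, only, known or untested is meant among the compounds shown, and "the series" means these compounds.

In a functional assay on HUVEC cells (Homo sapiens) for inhibition, with stated times of 2 h and 72 h (on this read-out lower numbers stand for stronger inhibition and higher numbers for weaker inhibition), compound 1 (`COc1cccc(Nc2nn(C)c3cc(Oc4ccnc5cc(OC)c(OC)cc45)ccc23)c1`) gives > 1000 nM, which is a limit and not a number. Compound 2 (`COc1cc2nccc(Oc3ccc4c(NC(=O)Nc5ccc(C)cc5)nn(C)c4c3)c2cc1OC`) gives > 1000 nM, again a limit. Compound 3 (`COc1cc2nccc(Oc3ccc4c(NCc5ccccc5)nn(C)c4c3)c2cc1OC`) gives > 1000 nM, a limit as well. Compound 1 therefore offers no exact starting value, and the three compounds cannot be ranked.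

Compound 4 (`COc1cc2nccc(Oc3ccc4c(NC(=O)c5ccc(C(F)(F)F)cc5)nn(C)c4c3)c2cc1OC`) keeps the core of compound 1 and changes one group on a nitrogen on an aromatic ring: (4-(trifluoromethyl)phenyl)carbonyl in place of 3-methoxyphenyl on a nitrogen on an aromatic ring. In words, (4-(trifluoromethyl)phenyl)carbonyl stands in place of 3-methoxyphenyl.

Two measured changes at the same place bear on this one. Among the measured compounds shown here, the first is a step that the two limits leave unreadable from compound 1 to compound 2. The second is a step that the two limits leave unreadable from compound 1 to compound 3. Neither has a readable size, so neither can be carried over to compound 4 as a number or a direction. The only firm observation is the limit of > 1000 nM in this assay, at which 3 of the 3 values shown sit, which makes another limit the likeliest result for compound 4.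

The expected change in this assay is a step that the limit leaves unreadable from compound 1 to compound 4, and no direction can be claimed for it. For compound 4 the estimated value is 2000 nM, with an expected range from 400 nM to 10000 nM.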

Compound 4, half-maximal inhibitory concentration: > 1000 nM
Compound 4: no number, only a limit; the forecaster's own chance of this, stated with the estimate: 70%; the middle value does not contradict the limit.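

Compound 4 also ends in a limit and not a number, so no step from compound 1, compound 2 or compound 3 to compound 4 can be read: the limit of > 1000 nM in this assay, at which 4 of the 4 values shown sit.

The compounds shown leave open how strongly each one inhibits in this assay, and whether any group on this nitrogen would give an exact number.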